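Methyl on the phenyl in the reversed amide series

The compounds below may be only part of what the source reports. "The series", "measured", "known", "first", "only" and "open" are said of these compounds alone.

Compound 1 `COc1ccccc1N1CCN(CCC(Oc2ccc(NC(=O)c3ccccc3OCCCC(=O)O)cc2)c2ccccc2)CC1` gives 730 nM in an assay on isolated protein for inhibition of steroid 5-alpha-reductase (Rattus norvegicus); a higher number here means a weaker inhibitor, a lower number a stronger inhibitor. Going by the values given here, compound 2 `COc1ccccc1N1CCN(CCC(Oc2ccc(NC(=O)c3ccccc3OCCCC(=O)O)cc2)c2ccc(C)cc2)CC1` carries methyl in place of hydrogen on an aromatic carbon and gives 440 nM in this assay; the step of a 1.7-fold lower number from compound 1 to compound 2 (0.22 log units; within the scatter) is the only measured instance of this kind of change. Compound 3 `COc1ccccc1N1CCN(CCC(Oc2ccc(C(=O)Nc3ccccc3OCCCC(=O)O)cc2)c2ccccc2)CC1` has the same atoms as compound 1 joined differently; the difference between the two cores is not broken down here. In this assay compound 3 gives 1000 nM, within the scatter of compound 1 and beyond it only against compound 2.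

Compound 4 `COc1ccccc1N1CCN(CCC(Oc2ccc(C(=O)Nc3ccccc3OCCCC(=O)O)cc2)c2cccc(C)c2)CC1` is not yet measured; it differs from compound 3 by methyl in place of hydrogen on an aromatic carbon. This is the same kind of change as from compound 1 to compound 2, but the place differs: there the methyl enters para to a large group, here meta to a large group. The expectation for compound 4 is a step of a 1.3-fold lower number from compound 3 to compound 4 (0.12 log units; within the scatter), resting on the small step of a 1.7-fold lower number from compound 1 to compound 2 (0.22 log units; within the scatter) with allowance for the changed place. Compound 4 is estimated at 750 nM, with a likely range from 380 nM to 1500 nM.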

Compound 4, half-maximal inhibitory concentration: 360 nM
The estimate for compound 4 lay 2.1-fold (0.32 log units) above the measured number; measured number outside the range, below it.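

Methyl in place of hydrogen on the phenyl gives a 2.8-fold lower number from compound 3 to compound 4 (0.44 log units; beyond the scatter) in this assay and so carries over to the second core without loss of the gain seen on the first. The size of the step does not separate the two cores: the same change on two cores in this assay, a 1.7-fold lower number (0.22 log units; within the scatter) from compound 1 to compound 2 and a 2.8-fold lower number (0.44 log units; beyond the scatter) from compound 3 to compound 4, 1.7-fold (0.22 log units) apart, within the scatter of two such steps

This rests on two pairs only, with the methyl at a different place in each, meta to a large group in compound 4, so core and place cannot be told apart and no general rule for the change follows.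

Open, as far as these compounds go, is whether methoxy or chlorine in place of the methyl on the same phenyl moves the number in the same way. Also open, from the compounds shown here alone, is how either core responds to a longer chain carrying the carboxylic acid.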